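The compounds below may be only part of what the source reports. "The series", "measured", "known", "first", "only" and "open" are said of these compounds alone.

Compound 1 `[O-][S+]1CC(Nc2nonc2/C(=N/O)Nc2ccc(F)c(Br)c2)C1` belongs to a set of three compounds that share one core and differ only in the group carried on a nitrogen on an aromatic ring. In an assay on isolated protein for inhibition of Indoleamine 2,3-dioxygenase 1 (Homo sapiens), read by fluorescence, with a stated time of 60 min (on this read-out lower numbers stand for stronger inhibition and higher numbers for weaker inhibition), compound 1 gives 212 nM. Compound 2 `N=S1(=O)CC(Nc2nonc2/C(=N/O)Nc2ccc(F)c(Br)c2)C1` gives 208 nM in this assay, and compound 3 `C#CCNS(=O)(=O)CCNc1nonc1/C(=N/O)Nc1ccc(F)c(Br)c1` gives 218 nM. All three numbers sit within the scatter of one another: the step of a 1.0-fold lower number from compound 1 to compound 2 (0.01 log units; within the scatter) is the nearest to compound 1, the step of a 1.0-fold higher number from compound 1 to compound 3 (0.01 log units; within the scatter) the furthest, and the step of a 1.0-fold higher number from compound 2 to compound 3 (0.02 log units; within the scatter) is of the same size.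

Compound 4 `O=S(=O)(CCNc1nonc1/C(=N/O)Nc1ccc(F)c(Br)c1)NO` is not yet measured. It differs from compound 1 in the same place as the others: a group of 7 heavy atoms (2 carbon, 1 nitrogen, 3 oxygen, 1 sulfur; no ring) in place of a group of 5 heavy atoms (3 carbon, 1 oxygen, 1 sulfur; one four-membered non-aromatic ring with 1 hetero atom), on a nitrogen on an aromatic ring

The three measured steps all bear on this change, since each swaps the group on that nitrogen, whether for a ring or for an open chain, and each stayed within the scatter. On that basis no step beyond the scatter is expected in this assay from compound 1 to compound 4; the expected step is a 1.0-fold lower number from compound 1 to compound 4 (0.00 log units; within the scatter). Compound 4 is therefore expected to give about 210 nM, within a range from 100 nM to 450 nM.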

Compound 4, half-maximal inhibitory concentration: 126 nM
Beside the measured number, compound 4's estimate is 1.7-fold (0.22 log units) above it, and the stated range covers the measured number.
By their numbers in this assay, from the lowest: compounds 4, 2, 1 and 3 (each within the scatter of the next).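

In this assay, the group on the nitrogen on an aromatic ring could be changed to 2-(hydroxysulfamoyl)ethyl, an open chain that carries hydrogen-bond donors absent from the group of compound 1, and the number stayed within the scatter (a 1.7-fold lower number from compound 1 to compound 4 (0.23 log units; within the scatter)), as it did against the ring of compound 2 (a 1.7-fold lower number from compound 2 to compound 4 (0.22 log units; within the scatter)). Going by these compounds alone, compound 3 and compound 4 add a narrower comparison that the earlier compounds did not offer, since they differ only on the sulfonamide nitrogen, where hydroxy stands in place of propargyl, and that step also stayed within the scatter (a 1.7-fold lower number from compound 3 to compound 4 (0.24 log units; within the scatter)). Across the four compounds, neither ring nor open chain, nor either of these two sulfonamide nitrogen groups, separates one number from another, and nothing available here accounts for the small differences that remain.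

The compounds shown leave open whether this flat picture would hold with a carboxylic acid or an amine in place of the sulfonamide, or with a chain longer than the ethyl linker. They also leave open whether a plain sulfonamide nitrogen, with hydrogen in place of hydroxy or propargyl, would stay within the scatter of these numbers.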